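Halogen swap on the methylsulfonyl aryl imidazolines

This account rests on a few compounds, and the source may have more. Where it says the series, first, only, none or still open, it means among the compounds named here.

Measured so far:
compound 1, `CS(=O)(=O)c1ccc(F)cc1NCC1=NCCN1`, 1320 nM
compound 2, `CS(=O)(=O)c1cc(F)ccc1NCC1=NCCN1`, 513 nM
compound 3, `CS(=O)(=O)c1ccc(Cl)cc1NCC1=NCCN1`, 2950 nM

Three compounds have been run in an assay for binding affinity to Alpha-1B adrenergic receptor (Homo sapiens), read by radioligand binding; a higher number here means a weaker inhibitor, a lower number a stronger inhibitor. Compound 2 has the lowest number of the three. Compound 1 and compound 2 have the same atoms joined differently; the difference between the two cores is not broken down here. From compound 1 to compound 3 the change is chloro in place of fluoro on an aromatic carbon, and the step is a 2.2-fold higher number from compound 1 to compound 3 (0.35 log units; beyond the scatter).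

Compound 4, `CS(=O)(=O)c1cc(Cl)ccc1NCC1=NCCN1`, has not yet been measured. It differs from compound 2 by chloro in place of fluoro on an aromatic carbon. This is the same kind of change as from compound 1 to compound 3, but the place is not the same: in compound 4 the carbon is meta to the methylsulfonyl group and para to the group of 7 heavy atoms, whereas in compound 3 it is meta to the group of 7 heavy atoms and para to the methylsulfonyl group.

Within the data shown here, the one measured pair shows a modest rise, and nothing measured speaks for another direction on the core of compound 2. For compound 4 in this assay a step of a 2.2-fold higher number from compound 2 to compound 4 (0.35 log units; beyond the scatter) is expected, resting on a 2.2-fold higher number from compound 1 to compound 3 (0.35 log units; beyond the scatter). Compound 4 is therefore estimated at 1150 nM, with a range from 500 nM to 2600 nM.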

Compound 4, inhibition constant: 646 nM
The estimate for compound 4 lay 1.8-fold (0.25 log units) above the measured number; the measured number falls inside the stated range.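

In this assay, chloro in place of fluoro on an aromatic carbon gives a 1.3-fold higher number from compound 2 to compound 4 (0.10 log units; within the scatter), so on the core of compound 2 the swap produces no readable difference. Set beside the earlier step, the result gives no sign that the change behaves differently on the two cores: the same change on two cores in this assay, a 2.2-fold higher number (0.35 log units; beyond the scatter) from compound 1 to compound 3 and a 1.3-fold higher number (0.10 log units; within the scatter) from compound 2 to compound 4, 1.8-fold (0.25 log units) apart, within the scatter of two such steps. This supports carrying the swap between these two cores only within the limits of the scatter; it does not show that the two steps are equal in size, and with a single pair on each core it says nothing about any further core or any other substituent.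

The compounds shown hold only fluoro and chloro, so it stays open how a bromo, methoxy or nitrile group would read on either core in this assay. Also open, as far as these compounds go, is whether the picture would hold if the methylsulfonyl group gave way to a sulfonamide or a carboxylic acid.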